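The compounds below may be only part of what the source reports. "The series", "measured", "known", "first", "only" and "open" are said of these compounds alone.

Working notes on the series. Compound 1 `CCOc1ccc2c(=O)c(-c3ccc(O)cc3)coc2c1` gives 300 nM in an assay on isolated protein (Cricetulus griseus) for inhibition of Monoamine oxidase (Homo sapiens); on this read-out higher numbers stand for weaker inhibition and lower numbers for stronger inhibition. Compound 2 `O=c1c(-c2ccc(O)cc2)coc2cc(OCCC3OCCCO3)ccc12` gives 7000 nM in this assay, and compound 3 `O=c1c(-c2ccc(O)cc2)coc2cc(OCCCBr)ccc12` gives 150 nM, the lowest of the three numbers, though its gap to compound 1 is within the scatter: a 2.0-fold lower number from compound 1 to compound 3 (0.30 log units; within the scatter). The large shifts sit elsewhere: a 23-fold higher number from compound 1 to compound 2 (1.37 log units; beyond the scatter) and a 47-fold lower number from compound 2 to compound 3 (1.67 log units; beyond the scatter).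

Compound 4 `C=CCOc1ccc2c(=O)c(-c3ccc(O)cc3)coc2c1` differs from compound 3 by vinyl in place of 2-bromoethyl on a saturated chain carbon bound to an oxygen on an aromatic ring. Among the measured compounds shown here, the step that bears on it is the small one, a 2.0-fold lower number from compound 1 to compound 3 (0.30 log units; within the scatter), since the alkoxy chain of compound 1 and the 3-bromopropoxy chain of compound 3 read alike; no step in this set involves an allyloxy chain, so the expectation is a shift in this assay no larger than the scatter, in no firm direction.

Compound 4 is therefore estimated at 250 nM, range 80 nM to 800 nM, an expected step of a 1.7-fold higher number from compound 3 to compound 4 (0.22 log units; within the scatter).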

Compound 4, half-maximal inhibitory concentration: 450 nM
Compound 4: the middle estimate sits 1.8-fold (0.26 log units) below what was measured; the range from low to high includes it.
By their numbers in this assay, from the lowest: compounds 3, 1 and 4 (each within the scatter of the next, the first and the last beyond it); then compound 2.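

In this assay, 3-bromopropoxy to allyloxy gives a step just beyond the scatter, a 3.0-fold higher number from compound 3 to compound 4 (0.48 log units; beyond the scatter), while vinyl in place of methyl stays within it, a 1.5-fold higher number from compound 1 to compound 4 (0.18 log units; within the scatter). Among the compounds shown, the ring-bearing chain of compound 2 remains the clear outlier, with a 16-fold lower number from compound 2 to compound 4 (1.19 log units; beyond the scatter). No available evidence accounts for these shifts.

As far as these compounds go, whether an amine or a carboxylic acid in place of vinyl would read like compound 4 or like compound 2 stays open, as does the reading of a longer unbranched chain without a ring.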